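Phenyl to 3,4,5-trimethoxyphenyl on a shared core

This account rests on a few compounds, and the source may have more. Where it says the series, first, only, none or still open, it means among the compounds named here.

- compound 1 `O=C1/C(=C\c2ccccc2)c2c(ncn2COCc2ccccc2)CCN1Cc1ccccc1`: 20400 nM
- compound 2 `O=C1/C(=C\c2ccccc2)c2c(ncn2COCc2ccccc2)CCN1Cc1ccc(-c2ccccc2)cc1`: 81000 nM

In a functional assay on BGC-823 cells (Homo sapiens) for inhibition, read by MTT assay, with a stated time of 72 h (on this read-out higher numbers stand for weaker inhibition and lower numbers for stronger inhibition), compound 1 holds the lower of the two numbers, at 20400 nM, and is the stronger inhibitor of the pair. Compound 3 `COc1cc(/C=C2\C(=O)N(Cc3ccccc3)CCc3ncn(COCc4ccccc4)c32)cc(OC)c1OC` keeps the core of compound 1 and differs from it in one place: 3,4,5-trimethoxyphenyl in place of phenyl on a double-bonded chain carbon bound to a double-bonded ring carbon. It carries 3,4,5-trimethoxyphenyl in place of phenyl on a double-bonded chain carbon bound to a double-bonded ring carbon. Among the compounds with values here, the only measured step, a 4.0-fold higher number from compound 1 to compound 2 (0.60 log units; beyond the scatter), is modest and beyond the scatter, but it is a different change, phenyl in place of hydrogen on an aromatic carbon. Within the data shown here, no step has been measured at the place altered in compound 3, so no step beyond the scatter is expected in this assay. The expected step is a 1.3-fold lower number from compound 1 to compound 3 (0.11 log units; within the scatter). Compound 3 is expected to give about 16000 nM, with an estimated range of 5000 nM to 50000 nM.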

Compound 3, half-maximal inhibitory concentration: 12900 nM
Estimate against measurement, compound 3: 1.2-fold (0.09 log units) above; low and high end bracket the measured number.
By their numbers in this assay, from the lowest: compounds 3 and 1 (each within the scatter of the next); then compound 2.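

Within the data shown here, at this position, on a double-bonded chain carbon bound to a double-bonded ring carbon, the earlier compounds gave no reading; in this assay, 3,4,5-trimethoxyphenyl in place of phenyl gives a 1.6-fold lower number from compound 1 to compound 3 (0.20 log units; within the scatter). The entering group has 12 heavy atoms against 6 and 3 hydrogen-bond acceptors against 0, yet this step lies within the scatter, whereas the phenyl added on an aromatic carbon elsewhere gave a 4.0-fold higher number from compound 1 to compound 2 (0.60 log units; beyond the scatter). Nothing at hand accounts for either result.

The compounds shown leave open whether an amine or a carboxylic acid on this aromatic ring would also give a step within the scatter. They also leave open how 3,4,5-trimethoxyphenyl at this position would read with the biphenyl-bearing group of compound 2 in place of the benzyl group.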